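Half-life after moving the fluorine on the anilino ring

The compounds below may be only part of what the source reports. "The series", "measured", "known", "first", "only" and "open" are said of these compounds alone.

Compound 1 `Fc1ccccc1Nc1nc(-c2ccccn2)cs1`: 0.103 h
Compound 2 `O=C(O)c1ccc(-c2csc(-c3ccccc3F)n2)cc1`: 3.24 h
Compound 3 `O=C(O)c1cccc(-c2csc(Nc3ccccc3F)n2)c1`: 1.61 h

In an ADME assay on microsomes from liver (Homo sapiens) for metabolic stability, read by LC-MS, using NADPH (on this read-out lower numbers stand for a shorter-lived compound and higher numbers for a longer-lived compound), compound 3 stands second highest of the three numbers. Compound 2 gives 3.24 h, which lies within the scatter of compound 3, so no order between the two can be claimed. Compound 1 gives 0.103 h, far below compound 3 and beyond the scatter. Compound 4 `O=C(O)c1cccc(-c2csc(Nc3ccc(F)cc3)n2)c1` differs from compound 3 in one place: 4-fluorophenyl in place of 2-fluorophenyl on a nitrogen on an aromatic ring. Among the compounds with values here, no measured pair shows this change, and no value of the three points to a direction for it. In this assay compound 4 is therefore expected to stay close to compound 3, with a step of a 1.2-fold lower number from compound 3 to compound 4 (0.06 log units; within the scatter), none beyond the scatter. Compound 4 is estimated at 1.4 h, with a range from 0.6 h to 3.5 h.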

Compound 4, half-life: 1.35 h
Estimate against measurement, compound 4: 1.0-fold (0.02 log units) above; low and high end bracket the measured number.
By their numbers in this assay, from the lowest: compound 1; then compounds 4, 3 and 2 (each within the scatter of the next, the first and the last beyond it).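

In this assay, within the data shown here, the move from 2-fluorophenyl to 4-fluorophenyl on a nitrogen on an aromatic ring gives a 1.2-fold lower number from compound 3 to compound 4 (0.08 log units; within the scatter) and is the first one-place comparison at this position. For these two groups, the half-life does not separate the two fluorine placements. No evidence bears on this result.

As far as these compounds go, whether a phenyl without fluorine, or a methoxy or an amine on that ring, would keep the half-life in the same range remains open. No pair shown isolates the contribution of the carboxylic acid on the core of compound 3.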